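Amino in place of chloro on compound 2

This account rests on a few compounds, and the source may have more. Where it says the series, first, only, none or still open, it means among the compounds named here.

Measured in an ADME assay on MT4 cells (Homo sapiens) for cytotoxicity, read by MTT assay; a higher number here means that more compound is tolerated, a lower number that less compound is tolerated:
Compound 1 `Cc1c(C(C)c2c(F)cccc2F)nc(N(C)C)[nH]c1=O`: > 17000 nM
Compound 2 `CC(c1cc(Cl)nc(Nc2ccc(C#N)cc2)n1)c1c(F)cccc1F`: > 2690 nM
Compound 3 `Cc1c(Cl)nc(Nc2ccc(C#N)cc2)nc1C(C)c1c(F)cccc1F`: > 13000 nM

All three entries are limits of the assay and not numbers, so they set no ranking. Compound 2 stands at > 2690 nM, which is a limit. Compound 4 `CC(c1cc(N)nc(Nc2ccc(C#N)cc2)n1)c1c(F)cccc1F` has yet to be measured in this assay. It carries amino in place of chloro on an aromatic carbon.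

Among the compounds with values here, only one measured step lies nearby. That step, a step that the two limits leave unreadable from compound 2 to compound 3, is methyl in place of hydrogen on an aromatic carbon, which is a different change, and its size cannot be read. Within the data shown here, no measured step therefore gives a size for the exchange of chloro for amino. Only a modest rise in the number is expected, an expectation resting on compound 3 at > 13000 nM, which is a limit. The expected size is a step that the limit leaves unreadable from compound 2 to compound 4, an estimate with wide uncertainty. Compound 4 is estimated at 9000 nM, with an expected range of 2500 nM to 35000 nM.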

Compound 4, half-maximal cytotoxic concentration: 46100 nM
Compound 4: middle estimate off by 5.1-fold (0.71 log units), on the low side; measured number outside the range, above it.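

In this assay compound 2 gives > 2690 nM, which is a limit of the assay and not a number. Within the data shown here, no step from compound 2 to compound 4 can therefore be read. The compounds shown leave open how large the effect of amino in place of chloro is in this assay.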